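Aryl in place of alkyl on the ring nitrogen

This account rests on a few compounds, and the source may have more. Where it says the series, first, only, none or still open, it means among the compounds named here.

Compound 1 `CCCOc1ccc(C(=O)Nc2cccc(C)n2)cc1` gives 11100 nM in an in vitro assay on HEK-tsA201 cells for antagonist activity at Neuronal acetylcholine receptor; alpha3/beta4 (Homo sapiens), read by fluorescence and calcium flux; a lower number here means a stronger inhibitor, a higher number a weaker inhibitor. Compound 2 `CCCCCNc1cccc(NC(=O)c2ccc(OCCC)cc2)n1` reaches only the limit > 100000 nM in this assay. Compound 3 `CCCCCCNc1cccc(NC(=O)c2ccc(OCCC)cc2)n1` stands at the limit > 100000 nM in this assay, so for compound 3 a limit is all that is known, and the limit of > 100000 nM in this assay, at which 2 of the 3 values shown sit, is where it sits. The steps of an at least 9.0-fold higher number from compound 1 to compound 2 (0.95 log units; beyond the scatter) and an at least 9.0-fold higher number from compound 1 to compound 3 (0.95 log units; beyond the scatter) each turned a measured number into a limit, whereas a step that the two limits leave unreadable from compound 2 to compound 3 cannot be read between two limits. Compound 4 `CCCOc1ccc(C(=O)Nc2cccc(Nc3ccc(Cl)cc3)n2)cc1` carries 4-chlorophenyl in place of hexyl on a nitrogen on an aromatic ring. Going by the values given here, no measured step exchanges an alkyl chain for an aromatic ring on that nitrogen; the two steps from compound 1 show only that pentylamino or hexylamino in place of methyl costs activity in this assay, and nothing tells whether an aromatic substituent on the same nitrogen behaves differently. Compound 4 is therefore expected to stay weak, with the step of an at least 1.6-fold lower number from compound 3 to compound 4 (0.22 log units; that floor lies within the scatter) estimated as small. Compound 4 is estimated at 60000 nM, between 15000 nM and 200000 nM, in this assay.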

Compound 4, half-maximal inhibitory concentration: > 100000 nM
Compound 4 gave a limit, no number; the forecaster's own chance of this, stated with the estimate: 45%; middle value at least 1.6-fold (0.22 log units) from the limit.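

Compound 4 also ends as a limit, not a number, in this assay: the limit of > 100000 nM in this assay, at which 3 of the 4 values shown sit.

The step of an at least 9.0-fold higher number from compound 1 to compound 4 (0.95 log units; beyond the scatter) is of the same kind as those to the pentylamino and hexylamino compounds, so the loss against compound 1 now extends from two alkyl chains to an aromatic ring on this nitrogen. The steps among compound 2, compound 3 and compound 4 cannot be read, as each joins two limits, and no order of pentyl, hexyl and 4-chlorophenyl follows from them.

On these data alone, it remains open whether the loss comes from the added nitrogen itself or from what that nitrogen carries. A plain amino or a methylamino group in place of the methyl of compound 1 would separate these two readings.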